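Swapping a Chlorophenyl for a Methylphenyl on a Shared Core

A few compounds are considered here, and "the series" means these few. Any claim that something is new, unique, unknown or untested is made for them only; others in the source may bear on it.

Of the compounds shown here, three built on a shared core have been tested in a functional assay on MOLT-4 cells (Homo sapiens) for cytotoxicity, read by CCK-8 assay, with a stated time of 72 h; on this read-out higher numbers stand for weaker inhibition and lower numbers for stronger inhibition. Compound 1 `C=CCn1c(=O)/c(=C\c2cccc(Cl)c2)[nH]c(=O)/c1=C\c1ccccc1OC` gives 4900 nM. Compound 2 `C=CCn1c(=O)/c(=C\c2ccccc2Cl)[nH]c(=O)/c1=C\c1ccccc1OC` gives 4400 nM, and compound 3 `C=CCn1c(=O)/c(=C\c2ccccc2OC)[nH]c(=O)/c1=C\c1ccccc1OC` gives 13100 nM. Among these three numbers compound 1 stands second highest: the step of a 1.1-fold lower number from compound 1 to compound 2 (0.05 log units; within the scatter) stays within the scatter, whereas the step of a 2.7-fold higher number from compound 1 to compound 3 (0.43 log units; beyond the scatter) lies beyond it.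

Compound 4 `C=CCn1c(=O)/c(=C\c2ccc(C)cc2)[nH]c(=O)/c1=C\c1ccccc1OC` has not yet been measured. It differs from compound 1 in a single place: 4-methylphenyl in place of 3-chlorophenyl on a double-bonded chain carbon bound to an aromatic carbon.

Within the data shown here, two measured steps bear on this change. Shifting the chloro group on the same ring, a 1.1-fold lower number from compound 1 to compound 2 (0.05 log units; within the scatter), produced no change beyond the scatter. Exchanging chloro for methoxy on that ring, a 3.0-fold higher number from compound 2 to compound 3 (0.47 log units; beyond the scatter), weakened inhibition modestly. Among the measured compounds shown here, no measured compound carries a 4-methylphenyl group, so its effect is not directly known; what the data show is that the ring position of a halogen matters little, while replacing chloro by another group cost some activity.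

The step of a 1.3-fold higher number from compound 1 to compound 4 (0.12 log units; within the scatter) is therefore expected to be small, leaning toward a weaker inhibitor. Compound 4 is estimated to give 6500 nM, with a range from 2500 nM to 17000 nM.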

Compound 4, half-maximal inhibitory concentration: "not active" (no number reported)
Compound 4: no number reported, and the estimate cannot be compared.
By their numbers in this assay, from the lowest: compounds 2 and 1 (each within the scatter of the next); then compound 3.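

In this assay, among these compounds, compound 4 is reported as "not active" with no number, so no step linking it to compound 1, 2 or 3 can be read. The compounds shown leave open how large the effect of 4-methylphenyl in place of 3-chlorophenyl is. No supporting data bear on this result.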